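A few compounds are considered here, and "the series" means these few. Any claim that something is new, unique, unknown or untested is made for them only; others in the source may bear on it.

Working notes on the thyrotropin receptor series.

The series is read in a functional assay on HEK293 cells for agonist activity at Thyrotropin receptor (Homo sapiens), read by cAMP accumulation; a higher number here means a larger maximal response, a lower number a smaller maximal response. Compound 1 `CSc1nc(-c2cccc(O)c2)c2c(N)c(C(=O)NC(C)(C)C)sc2n1` gives 11.2%. Compound 2 `CCOC(=O)c1sc2nc(SC)nc(-c3cccc(OC)c3)c2c1N` gives 1.5%, and compound 3 `COc1cccc(-c2nc(SC)nc3sc(C(=O)N(C)C(C)(C)C)c(N)c23)c1` gives 3.6%. Compound 1 carries the top number of the three, yet the gap to compound 3 and the gap to compound 2 both lie within the scatter, so the three numbers cannot be told apart.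

Going by the values given here, the one step between compounds that differ in a single place, a number 2.1 percentage points higher from compound 2 to compound 3 (within the scatter), concerns the group on the carbonyl carbon and stays within the scatter. It says nothing about the substituent on the phenyl ring.

Compound 4 `CSc1nc(-c2cccc(F)c2)c2c(N)c(C(=O)NC(C)(C)C)sc2n1` differs from compound 1 as follows: fluoro in place of hydroxy on an aromatic carbon. Among the compounds with values here, no measured pair in this set changes only that position; compound 1 carries hydroxy while compound 2 and compound 3 carry methoxy and also differ elsewhere, so their numbers bear only loosely on the change. All three values are low and within the scatter of one another, which gives no ground to expect movement in this assay. The estimated step of a number 3.2 percentage points lower from compound 1 to compound 4 (within the scatter) is expected to stay within the scatter. Compound 4 is therefore estimated at 8%, with a range from 1% to 18%.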

Compound 4, largest response reached (reported as efficacy), in percent of the reference or control that the assay uses: 8.1%
Compound 4: the middle estimate sits 0.1 percentage points below what was measured; the range from low to high includes it.
By their numbers in this assay, from the lowest: compounds 2, 3, 4 and 1 (each within the scatter of the next).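

Going by these compounds alone, the change from 3-hydroxyphenyl to 3-fluorophenyl is the first one at this position read with the rest of the structure held constant, and in this assay it gives a number 3.1 percentage points lower from compound 1 to compound 4 (within the scatter) with no step beyond the scatter. Hydroxy counts a hydrogen-bond donor and a hydrogen-bond acceptor and fluoro counts neither, yet this one pair shows no separable difference in maximal response on this aromatic carbon. No outside evidence bears on this result.

On these data alone, this single pair does not show whether any other group on this aromatic carbon can move the response beyond the scatter, and an amine, a carboxylic acid or a longer alkoxy chain there remains open. Also open, as far as these compounds go, is whether the change from hydroxy to fluoro reads the same when the tert-butyl amide of compound 1 and compound 4 is replaced by the ethyl ester of compound 2 or the methyl(tert-butyl)amino group of compound 3.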